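This account rests on a few compounds, and the source may have more. Where it says the series, first, only, none or still open, it means among the compounds named here.

Compound 3 `CC(CSc1nnc(-c2ccncc2)s1)C(=O)NCc1ccccc1Cl` stands only at a limit in an ADME assay on HepG2 cells (Homo sapiens) for cytotoxicity, with a stated time of 3 days; a lower number here means that less compound is tolerated, a higher number that more compound is tolerated. In this assay compound 3 gives > 50000 nM, which is a limit of the assay and not a number. The two other members of the series sit the same way. Compound 2 `O=C(CCSc1nnc(-c2ccncc2)s1)NCc1ccccc1Cl` gives > 50000 nM, a limit. Compound 1 `CC(Sc1nnc(-c2ccncc2)s1)C(=O)Nc1ccc(Cl)cc1Cl` gives > 50000 nM, also a limit. Within the data shown here, the one step within measured compounds, a step that the two limits leave unreadable from compound 2 to compound 3, is therefore unreadable in size, since (the limit of > 50000 nM in this assay, at which 3 of the 3 values shown sit).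

Compound 4 `CC(CSc1nnc(-c2ccncc2)s1)C(=O)Nc1ccccc1Cl` differs from compound 3 by 2-chlorophenyl in place of 2-chlorobenzyl on an amide-type nitrogen. Among the measured compounds shown here, no measured step bears directly on this change; compound 1, which also carries an aromatic ring directly on the amide nitrogen, shows only the limit. No step beyond the scatter is therefore expected in this assay, in either direction. Compound 4 is expected to give 50000 nM, within 20000 nM to 100000 nM. The expected step of a number no higher from compound 3 to compound 4 (the limit leaves the size open) is none beyond the scatter, most likely again reported as a limit.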

Compound 4, half-maximal cytotoxic concentration: > 50000 nM
Compound 4 ended at the assay's limit; the forecaster's own chance of this, stated with the estimate: 80%; the middle value lies on the limit itself.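

The step from compound 3 to compound 4 cannot be read in this assay, because both compounds stand at a limit: the limit of > 50000 nM in this assay, at which 4 of the 4 values shown sit.

The compounds shown leave open what concentration of any of them reaches the half-maximal cytotoxic level, and whether 2-chlorophenyl in place of 2-chlorobenzyl shifts it.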